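From Sulfonyl to Amide: Estimating Compound 4

A few compounds are considered here, and "the series" means these few. Any claim that something is new, unique, unknown or untested is made for them only; others in the source may bear on it.

Of the compounds shown here, three sharing one core have been measured in a functional assay on BXPC-3 cells (Homo sapiens) for inhibition, read by MTT assay, with a stated time of 7 days; a lower number here means a stronger inhibitor, a higher number a weaker inhibitor. Compound 1 `CCC(CC)S(=O)(=O)c1ccc(S(=O)(=O)N2CCC[C@@H](C(=O)N3CCC(F)(F)CC3)C2)cc1` gives 40 nM, compound 2 `O=C([C@@H]1CCCN(S(=O)(=O)c2ccc(S(=O)(=O)C3CCC3)cc2)C1)N1CCC(F)(F)CC1` gives 78 nM, and compound 3 `CC(C)S(=O)(=O)c1ccc(S(=O)(=O)N2CCC[C@@H](C(=O)N3CCC(F)(F)CC3)C2)cc1` gives 50 nM. Compound 3 holds the second highest number of the three, yet its steps to both neighbours stay within the scatter: a 1.3-fold higher number from compound 1 to compound 3 (0.10 log units; within the scatter) and a 1.6-fold lower number from compound 2 to compound 3 (0.19 log units; within the scatter), as does a 2.0-fold higher number from compound 1 to compound 2 (0.29 log units; within the scatter). All three steps change only the group attached to a sulfonyl sulfur.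

Compound 4 `CCN(CC)C(=O)c1ccc(S(=O)(=O)N2CCC[C@@H](C(=O)N3CCC(F)(F)CC3)C2)cc1` differs from compound 3 in another way: diethylcarbamoyl in place of isopropylsulfonyl on an aromatic carbon. The sulfonyl group itself is removed and an amide takes its place. Going by the values given here, no measured step covers this kind of exchange, so the measured data give no direct guide, and the step must be treated as uncertain. A wider step than any seen so far is possible in either direction, but a modest loss seems the more cautious expectation. Compound 4 is therefore estimated at 150 nM, within a range from 40 nM to 600 nM, meaning an expected step of a 3.0-fold higher number from compound 3 to compound 4 (0.48 log units; beyond the scatter).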

Compound 4, half-maximal inhibitory concentration: 240 nM
The estimate for compound 4 lay 1.6-fold (0.20 log units) below the measured number; low and high end bracket the measured number.
By their numbers in this assay, from the lowest: compounds 1, 3 and 2 (each within the scatter of the next); then compound 4.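

In this assay the group on this aromatic carbon, para to a large group, proves sensitive to more than the alkyl part on the sulfur: diethylcarbamoyl in place of the sulfonyl groups gives a 4.8-fold higher number from compound 3 to compound 4 (0.68 log units; beyond the scatter) and likewise a 3.1-fold higher number from compound 2 to compound 4 (0.49 log units; beyond the scatter) and also a 6.0-fold higher number from compound 1 to compound 4 (0.78 log units; beyond the scatter) with no exception among these compounds. Exchanges among the three sulfonyl groups all stayed within the scatter, so among the four compounds, leaving the sulfonyl series counts for more than the choice of isopropyl, cyclobutyl or pentan-3-yl. No measurement is available that explains this difference.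

The compounds shown leave open whether the loss belongs to the carbonyl that takes the sulfonyl's place or to the two ethyl groups on the amide nitrogen. A dimethylcarbamoyl group or a diethylsulfamoyl group on the same carbon would help separate these two parts.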